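Permeability notes on a furfurylamino-quinazoline series

A few compounds are considered here, and "the series" means these few. Any claim that something is new, unique, unknown or untested is made for them only; others in the source may bear on it.

Measured so far in a physicochemical assay for permeability, using PAMPA, at pH 7.4; a higher number here means that the compound crosses the layer faster, a lower number that the compound crosses the layer more slowly:
compound 1, `CC(C)Nc1nc(NCc2ccco2)c2ccc(Cl)cc2n1`, gives 1380 10^-6 cm/s;
compound 2, `CC(C)Nc1nc(NCc2ccco2)c2c(Cl)cccc2n1`, gives 1240 10^-6 cm/s;
compound 3, `Cc1ccc2c(NCc3ccco3)nc(NC(C)C)nc2c1`, gives 798 10^-6 cm/s.

Compounds 1 and 2 share the same atoms joined differently; the difference between the two cores is not broken down here, and their two values lie within the scatter of each other. One change is followed twice. From compound 1 to compound 3 it is methyl in place of chloro on an aromatic carbon, and in this assay it made a 1.7-fold lower number from compound 1 to compound 3 (0.24 log units; within the scatter).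

Compound 4, `Cc1cccc2nc(NC(C)C)nc(NCc3ccco3)c12`, is not yet measured. From compound 2 to compound 4 the change is methyl in place of chloro on an aromatic carbon. The surroundings differ: in the first pair the place is meta to a fused ring and para to a fused ring, in the second it is ortho to a fused ring and meta to a fused ring, so this is the same kind of change rather than the same change. Beside a 1.7-fold lower number from compound 1 to compound 3 (0.24 log units; within the scatter), a step of about a 1.7-fold lower number from compound 2 to compound 4 (0.22 log units; within the scatter) is expected, resting on the value of compound 2, 1240 10^-6 cm/s, and on the step from compound 1 to compound 3. Compound 4 is therefore estimated at 750 10^-6 cm/s, between 450 10^-6 cm/s and 1300 10^-6 cm/s.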

Compound 4, apparent permeability: 812 10^-6 cm/s
Estimate against measurement, compound 4: 1.1-fold (0.03 log units) below; low and high end bracket the measured number.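

In this assay methyl in place of chloro gives a 1.5-fold lower number from compound 2 to compound 4 (0.18 log units; within the scatter) on one core and a 1.7-fold lower number from compound 1 to compound 3 (0.24 log units; within the scatter) on the other, both within the scatter. Across these two pairs, at two different places on the ring, the change therefore stays inside the scatter, but this does not establish that it lowers the number at all, nor does it predict the outcome at any other place or on any other core. Nothing measured here offers an explanation for either step.

Groups other than chloro and methyl at these places remain open, for example an amine, a carboxylic acid or a longer chain, as does whether any of them would give a step beyond the scatter. Also open, from the compounds shown here alone, is whether methyl in place of chloro reads the same way on a core that carries something other than the furfurylamino group.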